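This account rests on a few compounds, and the source may have more. Where it says the series, first, only, none or still open, it means among the compounds named here.

Compound 3 `O=C(CCCN1CCC(n2c(SCC(=O)c3ccc(Cl)cc3)nc3ccccc32)CC1)c1ccc(F)cc1` stands second highest of three compounds in a functional assay on the whole organism (strain STD-ddY) for inhibition, with Mus musculus as the target, with a stated time of 5 min (on this read-out lower numbers stand for an effect already at smaller amounts and higher numbers for an effect only at larger amounts of compound), giving 5 mg/kg. Its nearest neighbour is compound 2 `CSc1nc2ccccc2n1C1CCN(CCCC(=O)c2ccc(F)cc2)CC1`, which gives 6.2 mg/kg, and the step of a 1.2-fold lower number from compound 2 to compound 3 (0.09 log units; within the scatter) lies within the scatter. Compound 1 `Cc1nc2ccccc2n1C1CCN(CCCC(=O)c2ccc(F)cc2)CC1` gives 0.85 mg/kg; the steps of a 7.3-fold higher number from compound 1 to compound 2 (0.86 log units; beyond the scatter) and a 5.9-fold higher number from compound 1 to compound 3 (0.77 log units; beyond the scatter) are both modest. Compound 4 `CCOC(=O)Sc1nc2ccccc2n1C1CCN(CCCC(=O)c2ccc(F)cc2)CC1` differs from compound 3 by ethoxycarbonyl in place of ((4-chlorophenyl)carbonyl)methyl on a sulfur. The step of a 1.2-fold lower number from compound 2 to compound 3 (0.09 log units; within the scatter) also altered what sits on the sulfur and stayed within the scatter, so it bears most directly on this change; the sulfur remains in place in compound 4. Compound 4 is therefore expected to stay close, with a 1.1-fold higher number from compound 3 to compound 4 (0.04 log units; within the scatter) not beyond the scatter. The estimate for compound 4 is 5.5 mg/kg, ranging from 2.5 mg/kg to 12 mg/kg.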

Compound 4, dose for half-maximal effect: 0.36 mg/kg
For compound 4 the middle estimate is 15-fold (1.18 log units) above the measured one; measured number outside the range, below it.
By their numbers in this assay, from the lowest: compound 4; then compound 1; then compounds 3 and 2 (each within the scatter of the next).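

The group on the sulfur matters after all: methyl and ((4-chlorophenyl)carbonyl)methyl there stay within the scatter of each other, yet ethoxycarbonyl gives a 14-fold lower number from compound 3 to compound 4 (1.14 log units; beyond the scatter) and a 17-fold lower number from compound 2 to compound 4 (1.24 log units; beyond the scatter). Against methyl on the aromatic carbon, (ethoxycarbonyl)sulfanyl gives a 2.4-fold lower number from compound 1 to compound 4 (0.37 log units; beyond the scatter), so a higher number than compound 1 does not follow from the sulfur alone, as compound 2 and compound 3 had suggested. Nothing measured here accounts for this.

As far as these compounds go, whether the carbonyl directly on the sulfur or the ethoxy part carries the step stays open. So does how acetyl or a dimethylcarbamoyl group on the sulfur would compare.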